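The source may hold more compounds than are shown below. What is called first, only, known or untested is meant among the compounds shown, and "the series" means these compounds.

Compound 1 `c1ccc(Nc2nccc(-c3ccco3)n2)cc1` is the starting point of this set. In a functional assay for inhibition, with Homo sapiens as the target (on this read-out lower numbers stand for stronger inhibition and higher numbers for weaker inhibition), compound 1 gives 32000 nM. Compound 2 `COc1cccc(Nc2nccc(-c3cccs3)n2)c1` is built on a different core, and the difference between the two cores is not broken down here; in this assay compound 2 gives 900 nM. Compound 3 `COc1cccc(Nc2nccc(-c3sccc3C)n2)c1` differs from compound 2 by methyl in place of hydrogen on an aromatic carbon. For compound 3 this assay reports only a limit, > 24000 nM, and not a number. That change brought an at least 26-fold higher number from compound 2 to compound 3 (1.42 log units; beyond the scatter), a step that ends at the limit of > 24000 nM in this assay, at which 1 of the 3 values shown sits.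

Compound 4 `Cc1cc(-c2ccco2)nc(Nc2ccccc2)n1` has not yet been measured. It differs from compound 1 by methyl in place of hydrogen on an aromatic carbon. Going by the values given here, this is the same kind of change as the one from compound 2 to compound 3, but not the same: there the methyl enters on a five-membered aromatic ring with 1 sulfur, here on a six-membered aromatic ring with 2 nitrogen. Among the compounds with values here, since compound 1 already gives 32000 nM, and the only measured example of this kind of change is an at least 26-fold higher number from compound 2 to compound 3 (1.42 log units; beyond the scatter), compound 4 is expected to move by a 1.9-fold higher number from compound 1 to compound 4 (0.27 log units; within the scatter). Compound 4 is estimated at 60000 nM, between 15000 nM and 240000 nM.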

Compound 4, half-maximal inhibitory concentration: 17700 nM
For compound 4 the middle estimate is 3.4-fold (0.53 log units) above the measured one; the range from low to high includes it.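

On the core of compound 1, methyl in place of hydrogen on the six-membered aromatic ring with 2 nitrogen gives a 1.8-fold lower number from compound 1 to compound 4 (0.26 log units; within the scatter) in this assay, so this pair shows no measurable effect of the change. Set beside the earlier step, the result shows that the size of this change does not carry over from one core to another in this series: the same change on two cores in this assay, an at least 26-fold higher number (1.42 log units; beyond the scatter) from compound 2 to compound 3 and a 1.8-fold lower number (0.26 log units; within the scatter) from compound 1 to compound 4, at least 48-fold (1.68 log units) apart, beyond the scatter of two such steps

It does not show what sets the two steps apart, for the methyl enters a different ring in each pair and the two pairs also differ in their cores, while the step to compound 3 ends at a limit and not at a number: the limit of > 24000 nM in this assay, at which 1 of the 4 values shown sits.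

The compounds shown leave open whether an amine or a longer chain on the same aromatic carbon would move compound 1 away from 32000 nM. They also leave open whether methyl on the six-membered aromatic ring with 2 nitrogen of compound 2 would behave as it does in compound 4.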